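The source may report more compounds than this note shows. Statements on the series, on what has been measured and on what is new or still open speak of the compounds shown alone.

Of the compounds shown here, three sharing one core have been tested in a functional assay on U-87MG ATCC cells (Homo sapiens) for cytotoxicity, read by MTT assay, with a stated time of 72 h; on this read-out lower numbers stand for stronger inhibition and higher numbers for weaker inhibition. Compound 1 `COc1ccc(OC)c(/C=N/NC(=O)Nc2ccc(Oc3ccnc(-c4nncn4CCN(C)C)c3)c(F)c2)c1` gives 6400 nM. Compound 2 `CN(C)CCn1cnnc1-c1cc(Oc2ccc(NC(=O)N/N=C/c3ccccc3O[N+](=O)[O-])cc2F)ccn1` gives 7150 nM, and the step of a 1.1-fold higher number from compound 1 to compound 2 (0.05 log units; within the scatter) is too small to mean anything. Compound 3 `CN(C)CCn1cnnc1-c1cc(Oc2ccc(NC(=O)N/N=C/c3ccc(F)cc3F)cc2F)ccn1` gives 1900 nM, the lowest of the three numbers, with a 3.4-fold lower number from compound 1 to compound 3 (0.53 log units; beyond the scatter) and a 3.8-fold lower number from compound 2 to compound 3 (0.58 log units; beyond the scatter) both beyond the scatter, so compound 3 is the most active of the three.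

Compound 4 `CN(C)CCn1cnnc1-c1cc(Oc2ccc(NC(=O)N/N=C/c3ccc(O)c(F)c3)cc2F)ccn1` differs from compound 3 in a single place:

3-fluoro-4-hydroxyphenyl in place of 2,4-difluorophenyl on a carbon with a double bond to nitrogen

Among the compounds with values here, the steps that bear on this are the two changes of the same aryl group that led to compound 3. Both replaced a ring carrying oxygen-containing groups with the 2,4-difluorophenyl and both lowered the number by a modest amount. Compound 4 moves back toward an oxygen-bearing ring, so a modest rise in the number is expected, with the single fluorine on the ring kept.

Compound 4 is therefore expected to give about 3500 nM in this assay, within a range of 1500 nM to 8000 nM, an expected step of a 1.8-fold higher number from compound 3 to compound 4 (0.27 log units; within the scatter).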

Compound 4, half-maximal inhibitory concentration: > 100000 nM
Compound 4: no number, only a limit; the forecaster's own chance of this, stated with the estimate: 5%; at least 28-fold (1.45 log units) between middle value and limit.
By their numbers in this assay, from the lowest: compound 3; then compounds 1 and 2 (each within the scatter of the next). At a limit, above all of these: compound 4.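

Compound 4 gives no number in this assay, only a limit of the assay: the limit of > 100000 nM in this assay, at which 1 of the 4 values shown sits. Read against that limit, the change from compound 3 is an at least 52-fold higher number from compound 3 to compound 4 (1.72 log units; beyond the scatter), and the steps from the other two compounds are an at least 15-fold higher number from compound 1 to compound 4 (1.19 log units; beyond the scatter) and an at least 13-fold higher number from compound 2 to compound 4 (1.14 log units; beyond the scatter), all of them large. The earlier compounds shown here showed only modest differences among the 2,5-dimethoxyphenyl, 2-(nitrooxy)phenyl and 2,4-difluorophenyl groups, whereas compound 4 shows that a change at this carbon can take the read-out out of the measurable range altogether, even though the 3-fluoro-4-hydroxyphenyl group has the same number of heavy atoms as the 2,4-difluorophenyl it replaces and differs from it by carrying a hydrogen-bond donor and acceptor.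

The compounds shown cannot separate the effect of the hydroxy group from that of the changed fluorine pattern, since both differ at once between compound 3 and compound 4. A 3-fluoro-4-methoxyphenyl group or a 4-aminophenyl group on the same carbon would show whether the loss is tied to the hydroxy group itself or also extends to other oxygen or nitrogen substituents on the ring.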